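The source may report more compounds than this note shows. Statements on the series, on what has been measured and on what is new or still open speak of the compounds shown alone.

Measured compounds in a functional assay on HCT-116 cells (Homo sapiens) for antiproliferative activity, read by MTT assay, with a stated time of 72 h; on this read-out higher numbers stand for weaker inhibition and lower numbers for stronger inhibition:
- compound 1 `CC(C)(C)OC(=O)N1CCN(C(=S)SCc2cn(C[C@H](O)[C@H]3OC(=O)C(OCc4ccccc4)=C3OCc3ccccc3)nn2)CC1`: compound 1 gives > 100000 nM
- compound 2 `COc1ccccc1-c1cn(C[C@H](O)[C@H]2OC(=O)C(OCc3ccccc3)=C2OCc2ccccc2)nn1`: compound 2 gives > 100000 nM
- compound 3 `COc1ccccc1-c1cn(C/C=C2\OC(=O)C(OCc3ccccc3)=C2OCc2ccccc2)nn1`: compound 3 gives > 100000 nM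

Notes on the series. For compound 2 the result in this assay is a limit of the assay and not a number. The result for compound 1 is likewise only a limit. The result for compound 3 is also only a limit. No two measured compounds differ in a single place, so no step between measured values can be drawn; what is shown is that all three sit at the same limit (the limit of > 100000 nM in this assay, at which 3 of the 3 values shown sit), and compound 2 therefore stands nowhere above or below the others on the numbers available.

The next compound is compound 4 `Cc1ccc(-c2cn(C[C@H](O)[C@H]3OC(=O)C(OCc4ccccc4)=C3OCc3ccccc3)nn2)cc1`. It differs from compound 2 by 4-methylphenyl in place of 2-methoxyphenyl on an aromatic carbon. Since every measured compound in this assay returns a limit, no shift beyond the scatter is expected from compound 2 to compound 4, and the step that the limit leaves unreadable from compound 2 to compound 4 is an expectation only. For compound 4 the expected value in this assay is 150000 nM, with a range from 50000 nM to 500000 nM, and most probably the assay will again report only a limit.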

Compound 4, half-maximal inhibitory concentration: > 100000 nM
Compound 4: a limit, no number; the forecaster's own chance of this, stated with the estimate: 85%; the middle value lies beyond the limit too.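

Compound 2 and compound 4 both return only a limit, so no step can be read between them: the limit of > 100000 nM in this assay, at which 4 of the 4 values shown sit.

The compounds shown leave open how far any of the four lies beyond that limit, and whether 4-methylphenyl and 2-methoxyphenyl differ at all.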